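The source may report more compounds than this note shows. Statements on the series, on what has been measured and on what is new or still open speak of the compounds shown alone.

Measured in an ADME assay on L02 cells (Homo sapiens) for cytotoxicity, read by MTT assay, with a stated time of 24 h; a higher number here means a weaker inhibitor, a lower number a stronger inhibitor
compound 1 `COc1cc(/C=C2\CN(C)C/C(=C\c3ccc(Br)cc3)C2=O)cc(OC)c1OC` at 15400 nM
compound 2 `COc1cc(/C=C2\CN(C)C/C(=C\c3ccc(Cl)cc3Cl)C2=O)cc(OC)c1OC` at 13400 nM
compound 3 `COc1cc(/C=C2\CN(C)C/C(=C\c3cccc([N+](=O)[O-])c3)C2=O)cc(OC)c1OC` at 13600 nM

Going by the values given here, compound 3 stands level with the other two, with gaps of a 1.1-fold lower number from compound 1 to compound 3 (0.05 log units; within the scatter) and a 1.0-fold higher number from compound 2 to compound 3 (0.01 log units; within the scatter) on the numbers so far. Compound 4 `COc1cc(/C=C2\CN(C)C/C(=C\c3ccc(C#N)cc3)C2=O)cc(OC)c1OC` carries the change 4-cyanophenyl in place of 3-nitrophenyl on a double-bonded chain carbon bound to a double-bonded ring carbon with 4-cyanophenyl in place of 3-nitrophenyl on a double-bonded chain carbon bound to a double-bonded ring carbon. All three measured steps at this place bear on it, and a 1.1-fold lower number from compound 1 to compound 2 (0.06 log units; within the scatter) is likewise small. No step beyond the scatter is therefore expected, and the estimated step is a 1.0-fold higher number from compound 3 to compound 4 (0.01 log units; within the scatter) in this assay on that basis. Compound 4 is estimated at 14000 nM within an expected range (9000 nM to 21000 nM).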

Compound 4, half-maximal inhibitory concentration: 18600 nM
The estimate for compound 4 lay 1.3-fold (0.12 log units) below the measured number, and the stated range covers the measured number.
By their numbers in this assay, from the lowest: compounds 2, 3, 1 and 4 (each within the scatter of the next).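

Across the series (this assay) 4-cyanophenyl on a double-bonded chain carbon bound to a double-bonded ring carbon stays within the scatter of 3-nitrophenyl (a 1.4-fold higher number from compound 3 to compound 4 (0.14 log units; within the scatter)) and 2,4-dichlorophenyl (a 1.4-fold higher number from compound 2 to compound 4 (0.14 log units; within the scatter)). Cyano in place of bromo on an aromatic carbon likewise gives no separation (a 1.2-fold higher number from compound 1 to compound 4 (0.08 log units; within the scatter)), so a nitrile joins the halogen and nitro groups in a flat set of four compounds. No measurement on hand offers an account of these small steps. Still open, as far as these compounds go, is whether an aromatic ring carrying an amine or a carboxylic acid, or a longer chain in place of the aromatic ring, would give a step beyond the scatter at this place.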